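Swapping the Pyridine Arm on a Potassium Channel Inhibitor

The source may report more compounds than this note shows. Statements on the series, on what has been measured and on what is new or still open speak of the compounds shown alone.

Of the compounds shown here, two with a shared amide-linked core have been tested in an assay on T-REx-293 cells for inhibition of potassium channel subfamily T member 1 (Homo sapiens), read by patch clamp; on this read-out lower numbers stand for stronger inhibition and higher numbers for weaker inhibition. Compound 1 `Cc1cccc(-c2noc(C(C)NC(=O)c3cc(C4CC4)nn3C)n2)c1` gives 1880 nM in this assay. Compound 2 `Cc1cccc(-c2noc([C@H](C)NC(=O)c3cc(C(F)(F)F)nn3C)n2)n1` returns only a limit in this assay, > 30000 nM, so no firm number is known for it. Compound 2 thus sits at the limit of > 30000 nM in this assay, at which 1 of the 2 values shown sits, the weaker edge of what was measured. Compound 1 is the only one of the two with a definite value. Compound 3 `C[C@H](NC(=O)c1cc(C(F)(F)F)nn1C)c1nc(-c2ccnc(N(C)C)c2)no1` has not yet been measured. It differs from compound 2 in one place: 2-(dimethylamino)pyridin-4-yl in place of 6-methylpyridin-2-yl on an aromatic carbon. For the measured compounds named here, no measured pair differing in exactly one place exists here, so the step has no direct precedent. Because compound 2 stands at the limit of > 30000 nM in this assay, at which 1 of the 2 values shown sits, any definite number for compound 3 would already mean stronger inhibition. The step of an at least 3.7-fold lower number from compound 2 to compound 3 (0.57 log units; beyond the scatter) is expected to go toward stronger inhibition, beyond the usual scatter. Compound 3 is estimated at 8000 nM, with a likely range from 1500 nM to 30000 nM.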

Compound 3, half-maximal inhibitory concentration: 454 nM
For compound 3 the middle estimate is 18-fold (1.25 log units) above the measured one; measured number outside the range, below it.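

The aromatic carbon of the five-membered ring turns out to matter a great deal in this assay: putting 2-(dimethylamino)pyridin-4-yl in place of 6-methylpyridin-2-yl gives an at least 66-fold lower number from compound 2 to compound 3 (1.82 log units; beyond the scatter). For the compounds shown here, this is the first step here between compounds that differ in one place, so it ties a clear gain in inhibition to this single swap of groups. Its true size stays unknown, because compound 2 has only a limit and no firm number: the limit of > 30000 nM in this assay, at which 1 of the 3 values shown sits.

The swap changes two things at once, the substituent on the pyridine and the point at which the pyridine is attached, and the compounds shown cannot tell which of these counts. A 2-methylpyridin-4-yl group or a 2-methoxypyridin-4-yl group at the same carbon would help to pull those two changes apart.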